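A few compounds are considered here, and "the series" means these few. Any claim that something is new, unique, unknown or untested is made for them only; others in the source may bear on it.

Compound 2 `CCc1nc(C)c(CN2CCN(c3cccc4[nH]c(-c5ccc(C(C)(C)C)cc5)nc34)CC2)o1` and compound 1 `Cc1nc(C)c(CN2CCN(c3cccc4[nH]c(-c5ccc(C(C)(C)C)cc5)nc34)CC2)o1` share one core and differ only in the chain carbon that carries an ethyl in place of a methyl. In an assay on isolated protein for displacement of a labelled ligand from Gonadotropin-releasing hormone receptor (Rattus norvegicus) (a lower number here means a stronger inhibitor, a higher number a weaker inhibitor), compound 1 gives 740 nM, while compound 2 gives 320 nM, so a 2.3-fold lower number from compound 1 to compound 2 (0.36 log units; beyond the scatter) marks a modest gain. Among the compounds with values here, compound 2 therefore has the lower of the two numbers in this assay, with compound 1 as its only neighbour.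

Compound 3 `CCc1cc(CN2CCN(c3cccc4[nH]c(-c5ccc(C(C)(C)C)cc5)nc34)CC2)n(C)n1` keeps the core and the ethyl but exchanges the five-membered aromatic ring: 3-ethyl-1-methyl-1H-pyrazol-5-yl in place of 2-ethyl-4-methyl-1,3-oxazol-5-yl on a saturated chain carbon bound to an amine nitrogen in a ring. Within the data shown here, no measured step exchanges a ring in this way; the only step on record adjusts an ethyl on the same ring, and it bears on this change only weakly. An unchanged number, or a small shift either way within the scatter, is the expectation: compound 3 is estimated at 400 nM, between 130 nM and 1300 nM in this assay, which would mean an expected step of a 1.3-fold higher number from compound 2 to compound 3 (0.10 log units; within the scatter).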

Compound 3, half-maximal inhibitory concentration: 250 nM
Estimate against measurement, compound 3: 1.6-fold (0.20 log units) above; measured number inside the range.
By their numbers in this assay, from the lowest: compounds 3 and 2 (each within the scatter of the next); then compound 1.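

Exchanging 2-ethyl-4-methyl-1,3-oxazol-5-yl for 3-ethyl-1-methyl-1H-pyrazol-5-yl gives a 1.3-fold lower number from compound 2 to compound 3 (0.11 log units; within the scatter) in this assay, so at this place, on a saturated chain carbon bound to an amine nitrogen in a ring, these two five-membered aromatic rings cannot be told apart. Against 2,4-dimethyl-1,3-oxazol-5-yl, the same pyrazole group gives a 3.0-fold lower number from compound 1 to compound 3 (0.47 log units; beyond the scatter), so compound 3 keeps the lead over compound 1 that compound 2 already held. Nothing measured on these compounds offers a reason for this result.

Still open, as far as these compounds go, is whether a methyl in place of the ethyl on the pyrazole would weaken binding as it does on the oxazole. Also open, from the compounds shown here alone, is how a propyl chain in place of the ethyl, or a pyridine in place of the five-membered ring, would fare in this assay.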